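Arylamino replacements for pentyloxy on the shared core

The source may report more compounds than this note shows. Statements on the series, on what has been measured and on what is new or still open speak of the compounds shown alone.

Compound 1 `CCCCCOC1=C(C(=O)c2ccccc2)C(c2ccc(Br)cc2)N(CCCn2ccnc2)C1=O` is the reference point of this set. Among the measured compounds shown here, in a functional assay on SAOS-2 cells (Homo sapiens) for antiproliferative activity, read by MTT assay, with a stated time of 72 h (a lower number here means a stronger inhibitor, a higher number a weaker inhibitor), compound 1 gives 9990 nM, the lowest of the three numbers measured so far. Compound 2 `NC1=C(C(=O)c2ccccc2)C(c2ccc(Br)cc2)N(CCCn2ccnc2)C1=O` gives 107000 nM and compound 3 `Cc1ccc(NC2=C(C(=O)c3ccccc3)C(c3ccc(Br)cc3)N(CCCn3ccnc3)C2=O)cc1` gives 31900 nM; the step of an 11-fold higher number from compound 1 to compound 2 (1.03 log units; beyond the scatter) is large, the step of a 3.2-fold higher number from compound 1 to compound 3 (0.50 log units; beyond the scatter) modest, and the step of a 3.4-fold lower number from compound 2 to compound 3 (0.53 log units; beyond the scatter) shows that an aryl group on the amine nitrogen recovers part of what the bare amino loses.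

Compound 4 `O=C(C1=C(Nc2ccccc2Br)C(=O)N(CCCn2ccnc2)C1c1ccc(Br)cc1)c1ccccc1` has not yet been measured. It differs from compound 1 by (2-bromophenyl)amino in place of pentyloxy on a double-bonded ring carbon. For the measured compounds named here, the closest precedent is compound 3, where a (4-methylphenyl)amino replaced the same pentyloxy and produced the step of a 3.2-fold higher number from compound 1 to compound 3 (0.50 log units; beyond the scatter); the bare amino of compound 2 gave the larger step of an 11-fold higher number from compound 1 to compound 2 (1.03 log units; beyond the scatter). Another arylamino is therefore expected to fall between these, most likely near the modest step seen for compound 3, with a higher number than compound 1. For compound 4 the expected step is a 3.0-fold higher number from compound 1 to compound 4 (0.48 log units; beyond the scatter), and the estimate is 30000 nM within a range of 10000 nM to 90000 nM.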

Compound 4, half-maximal inhibitory concentration: 19600 nM
Compound 4: middle estimate off by 1.5-fold (0.18 log units), on the high side; the range from low to high includes it.
By their numbers in this assay, from the lowest: compounds 1, 4 and 3 (each within the scatter of the next, the first and the last beyond it); then compound 2.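

In this assay the (2-bromophenyl)amino group gives a 2.0-fold higher number from compound 1 to compound 4 (0.29 log units; within the scatter) and so cannot be separated from pentyloxy at this position, which the arylamino of compound 3 could not show, since its step from compound 1 lies beyond the scatter. The two aryl groups on the amine nitrogen also cannot be told apart, with a 1.6-fold lower number from compound 3 to compound 4 (0.21 log units; within the scatter), while the recovery from the bare amino now appears with a second aryl group, as a 5.5-fold lower number from compound 2 to compound 4 (0.74 log units; beyond the scatter). No measurement on hand accounts for any of these steps.

Going by these compounds, whether a cyclic amine such as morpholine, or a chain longer than pentyloxy such as octyloxy, would give a number clearly lower than that of compound 1 remains open. Also open, on these data alone, is how a carboxylic acid on the aryl ring of the arylamino would read in this assay.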